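Swapping isobutylamino for butylsulfanyl on the shared core

The source may hold more compounds than are shown below. What is called first, only, known or untested is meant among the compounds shown, and "the series" means these compounds.

In an ADME assay on Akata cells (Homo sapiens) for cytotoxicity, with a stated time of 7 days (on this read-out higher numbers stand for lower toxicity in this test and lower numbers for higher toxicity in this test), compound 1 `CCCSc1nc(N)nc2c1ncn2/C=C1/CC1(CO)CO` gives > 20000 nM as a limit. Within the data shown here, compound 2 `CC(C)CNc1nc(N)nc2c1ncn2/C=C1/CC1(CO)CO` gives > 24000 nM as a limit too, so it stands without a number, as does the one other value beside it. Among the measured compounds shown here, the only measured step that the two limits leave unreadable from compound 1 to compound 2 bears on the change ahead, and it offers no size to carry forward. Compound 3 `CCCCSc1nc(N)nc2c1ncn2/C=C1/CC1(CO)CO` takes butylsulfanyl in place of isobutylamino on an aromatic carbon and so returns to a sulfanyl chain. Compound 1, which carries propylsulfanyl, reads > 20000 nM as a limit, and this is the closest guide available. No step beyond the usual scatter is therefore expected in this assay and no direction can be called, so the estimated step of an at least 1.0-fold lower number from compound 2 to compound 3 (0.03 log units; that floor lies within the scatter) is small. For compound 3 the estimate is 22000 nM with an expected range from 10000 nM to 50000 nM and quite possibly another limit as the reported result.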

Compound 3, half-maximal cytotoxic concentration: > 20000 nM
Compound 3: only a limit was reported (the forecaster's own chance of this, stated with the estimate: 75%); the middle value is on the limit's open side.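

In this assay compound 3 gives > 20000 nM, which is a limit, so its steps from compound 1 and from compound 2 cannot be read. The compounds shown leave open where any of the three truly stands in this assay, and whether butylsulfanyl, propylsulfanyl and isobutylamino differ there at all.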